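Alkynyl uracils with a phthalimide tether: geometry and chain end

The compounds below may be only part of what the source reports. "The series", "measured", "known", "first", "only" and "open" are said of these compounds alone.

Three members of the series have been run in a functional assay on L1210 cells (Mus musculus) for antiproliferative activity, read by MTT assay, with a stated time of 2 days; on this read-out lower numbers stand for stronger inhibition and higher numbers for weaker inhibition. Compound 1 `CCCCC#Cc1cn(C/C=C\CN2C(=O)c3ccccc3C2=O)c(=O)[nH]c1=O` gives 109000 nM. Compound 2 `O=C1c2ccccc2C(=O)N1C/C=C\Cn1cc(C#CCCc2ccccc2)c(=O)[nH]c1=O` gives 143000 nM. Compound 3 `O=C1c2ccccc2C(=O)N1C/C=C/Cn1cc(C#CCCc2ccccc2)c(=O)[nH]c1=O` gives 44000 nM, the lowest number of the three, and its steps to the other two lie beyond the usual scatter.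

Two changes are covered. The first is ethyl in place of phenyl on a saturated chain carbon, two bonds along the chain from a triple-bonded carbon; it moved the read-out by a 1.3-fold lower number from compound 2 to compound 1 (0.12 log units; within the scatter). The second is the two compounds have the same atoms and bonds and differ only in configuration as drawn: 1 of 1 stereo elements differ; a double bond is drawn Z in compound 2 and E in compound 3; here the read-out moved by a 3.3-fold lower number from compound 2 to compound 3 (0.51 log units; beyond the scatter). That the two compounds differ only in the configuration as drawn the fact that compounds 2 and 3 differ only in the configuration as drawn is the whole of what separates compound 2 from compound 3.

Compound 4 `CCCCC#Cc1cn(C/C=C/CN2C(=O)c3ccccc3C2=O)c(=O)[nH]c1=O` is not yet measured. It stands to compound 3 as compound 1 stands to compound 2: the change is ethyl in place of phenyl on a saturated chain carbon, two bonds along the chain from a triple-bonded carbon, at the same place in both pairs. The cores on which the change is made differ from each other by the two compounds have the same atoms and bonds and differ only in configuration as drawn: 1 of 1 stereo elements differ; a double bond is drawn Z in compound 2 and E in compound 3, so it is the same kind of change on the other geometry.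

Since the change from compound 2 to compound 1 gave a 1.3-fold lower number from compound 2 to compound 1 (0.12 log units; within the scatter), a step of similar size is expected here: from compound 3 to compound 4 the expected step is a 1.3-fold lower number from compound 3 to compound 4 (0.11 log units; within the scatter). The estimate for compound 4 in this assay is therefore 34000 nM, with a likely range from 15000 nM to 90000 nM.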

Compound 4, half-maximal inhibitory concentration: 236000 nM
Beside the measured number, compound 4's estimate is 6.9-fold (0.84 log units) below it; measured number above the stated range.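

In this assay, the change from phenyl to ethyl on the core with the double bond drawn E gave a 5.4-fold higher number from compound 3 to compound 4 (0.73 log units; beyond the scatter), so the small step seen on the Z core did not carry over, and the two steps differ: the same change on two cores in this assay, a 1.3-fold lower number (0.12 log units; within the scatter) from compound 2 to compound 1 and a 5.4-fold higher number (0.73 log units; beyond the scatter) from compound 3 to compound 4, 7.0-fold (0.85 log units) apart, beyond the scatter of two such steps

The same split appears when the chain end is held fixed, since the move from Z to E gave a 3.3-fold lower number from compound 2 to compound 3 (0.51 log units; beyond the scatter) with the 4-phenylbut-1-yn-1-yl end but a 2.2-fold higher number from compound 1 to compound 4 (0.34 log units; beyond the scatter) with the hex-1-yn-1-yl end, a step in the opposite direction: the fact that compounds 1 and 4 differ only in the configuration as drawn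

For the compounds shown here, for these four compounds, then, the effect of the chain end cannot be read independently of the double-bond geometry, and a step measured on one geometry is a poor guide to the other; the data do not show why this is so, nor, with only one pair on each geometry, whether it holds for any other pair of chain ends.

The compounds shown leave open whether a longer chain, or a chain end carrying an amine or a carboxylic acid, would follow the same split between the two geometries. They also leave open how the series would respond if the double bond of the tether gave way to a saturated chain or a triple bond, or if the phthalimide gave way to a simple amide.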